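This account rests on a few compounds, and the source may have more. Where it says the series, first, only, none or still open, it means among the compounds named here.

Compound 1 `Nc1cccc(CNc2cc(C(F)(F)F)cc3[nH]ncc23)c1` is the starting point. In an assay for inhibition of Tryptophan 2,3-dioxygenase (Homo sapiens), with stated times of 10 min and 60 min, tested at 10 uM (a lower number here means a weaker effect, a higher number a stronger effect of the compound at the concentration tested), compound 1 gives 68%, the second highest of the three numbers shown. Its nearest neighbour is compound 2 `Oc1ccc(CNc2cc(C(F)(F)F)cc3[nH]ncc23)cc1`, which in this assay gives 75%; the furthest is compound 3 `O=[N+]([O-])c1ccccc1CNc1cc(Br)cc2[nH]ncc12`, which gives 52%, a lower number that lies beyond the scatter. Within the data shown here, the single step between measured compounds that differ in one place is a number 7 percentage points higher from compound 1 to compound 2 (within the scatter), a change of 4-hydroxyphenyl in place of 3-aminophenyl.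

Compound 4 `O=[N+]([O-])c1cccc(CNc2cc(C(F)(F)F)cc3[nH]ncc23)c1` is not yet measured. It differs from compound 1 as follows: nitro in place of amino on an aromatic carbon. Among the measured compounds shown here, no measured step exchanges a nitro for an amino, so the only guidance is indirect. The step from compound 1 to compound 2 shows that exchanging one group on this aromatic ring for another moved the number only within the scatter. For the measured compounds named here, compound 3 also carries a nitro, but it differs from compound 1 in more than one place, and its values with compound 1 show only that a nitro-bearing compound can give a lower number. Taken together, the account expects for compound 4 a step of a number 6 percentage points lower from compound 1 to compound 4 (within the scatter), estimated as a small decrease that may well stay within the scatter. The expected value for compound 4 is 62%, with a range from 45% to 78%.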

Compound 4, a percentage reported as inhibition, at one concentration (the size of the read-out at that concentration, not a potency): 60%
Compound 4: the middle estimate sits 2 percentage points above what was measured; low and high end bracket the measured number.
By their numbers in this assay, from the lowest: compounds 3, 4, 1 and 2 (each within the scatter of the next, the first and the last beyond it).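

In this assay, the exchange on this aromatic carbon, meta to a large group, gives a number 8 percentage points lower from compound 1 to compound 4 (within the scatter). The earlier compounds held no step of this kind; this one shows that a nitro, with 3 heavy atoms and 0 hydrogen-bond donors, can replace an amino, with 1 heavy atom and 1 hydrogen-bond donor, without a change beyond the scatter, so the hydrogen-bond donor of the amino is not shown to be required at this position. Nothing measured here explains this step.

The compounds shown leave open whether a carboxylic acid, a nitrile or a methoxy group on the same aromatic carbon would also stay within the scatter of compound 1. They also leave open how the same exchange would read with bromo in place of trifluoromethyl on the core.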